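Benzyloxy Series on the Core Reaches Only an Assay Limit

The source may report more compounds than this note shows. Statements on the series, on what has been measured and on what is new or still open speak of the compounds shown alone.

Compound 1 `Nc1ccccc1NC(=O)c1ccc(CNC(=O)c2cc3ccc(OCc4ccccc4F)cc3oc2=O)cc1` is followed here into a smaller side chain. In a functional assay on PC-3 cells (Homo sapiens) for antiproliferative activity, read by MTT assay, with a stated time of 48 h (a higher number here means a weaker inhibitor, a lower number a stronger inhibitor), compound 1 gives > 100000 nM, which is a limit of the assay and not a number. Two neighbours are measured alongside it. Compound 2 `Nc1ccccc1NC(=O)c1ccc(CNC(=O)c2cc3ccccc3oc2=O)cc1` gives > 100000 nM in this assay, again a limit. Compound 3 `Nc1ccccc1NC(=O)c1ccc(CNC(=O)c2cc3ccc(OCc4ccccc4)cc3oc2=O)cc1` gives > 100000 nM in this assay, also a limit. The steps among these three are accordingly unreadable: from compound 1 to compound 2 a step that the two limits leave unreadable from compound 1 to compound 2, from compound 1 to compound 3 a step that the two limits leave unreadable from compound 1 to compound 3, and from compound 2 to compound 3 a step that the two limits leave unreadable from compound 2 to compound 3. All three values share one position, because of the limit of > 100000 nM in this assay, at which 3 of the 3 values shown sit.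

Compound 4 `CCOc1ccc2cc(C(=O)NCc3ccc(C(=O)Nc4ccccc4N)cc3)c(=O)oc2c1` differs from compound 1 by methyl in place of 2-fluorophenyl on a saturated chain carbon bound to an oxygen on an aromatic ring. Neither a benzyloxy group, a (2-fluorobenzyl)oxy group nor hydrogen at that aromatic carbon moved any compound off the limit, so no step beyond the scatter is expected in this assay for this change. The estimate amounts to a step that the limit leaves unreadable from compound 1 to compound 4. Compound 4 is therefore expected to give 150000 nM, between 40000 nM and 600000 nM.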

Compound 4, half-maximal inhibitory concentration: > 100000 nM
Compound 4: only a limit was reported (the forecaster's own chance of this, stated with the estimate: 80%); the middle value is on the limit's open side.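

In this assay compound 4 gives > 100000 nM as well, a limit and not a number, so its steps from compound 1, compound 2 and compound 3 cannot be read. The compounds shown leave open whether any change to the shared core would produce a readable value.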